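A few compounds are considered here, and "the series" means these few. Any claim that something is new, unique, unknown or untested is made for them only; others in the source may bear on it.

Compound 1 `CC(O)(COc1ccccc1C(F)(F)F)C(=O)Nc1ccc(S(F)(F)(F)(F)F)cc1`: 1400 nM
Compound 2 `CC(O)(COc1ccccc1OC(F)(F)F)C(=O)Nc1ccc(S(F)(F)(F)(F)F)cc1`: 7300 nM

For the measured compounds named here, in a functional assay on CWR22R cells (Homo sapiens) for antiproliferative activity, read by propidium iodide staining, with a stated time of 96 h (a lower number here means a stronger inhibitor, a higher number a weaker inhibitor), compound 1 has the lowest number so far. Compound 3 `CC(O)(COc1ccc(C#N)cc1C(F)(F)F)C(=O)Nc1ccc(S(F)(F)(F)(F)F)cc1` is compound 1 with cyano in place of hydrogen on an aromatic carbon, para to a large group and meta to a trifluoromethyl group: cyano in place of hydrogen on an aromatic carbon. Going by the values given here, the only measured step is a 5.2-fold higher number from compound 1 to compound 2 (0.72 log units; beyond the scatter), a modest one beyond the scatter. It shows that one group swapped on an aromatic carbon can move the number, but it involves no cyano and gives no direction. A step of similar size either way remains possible, though none beyond the scatter is expected. The expected step is a 1.2-fold lower number from compound 1 to compound 3 (0.07 log units; within the scatter). For compound 3 the estimate is 1200 nM, with an expected range from 300 nM to 5000 nM.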

Compound 3, half-maximal inhibitory concentration: 13800 nM
The estimate for compound 3 lay 12-fold (1.06 log units) below the measured number, outside the stated range (above it).
By their numbers in this assay, from the lowest: compound 1; then compounds 2 and 3 (each within the scatter of the next).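

In this assay, placing cyano on this aromatic carbon, para to a large group and meta to a trifluoromethyl group, gives a 9.9-fold higher number from compound 1 to compound 3 (0.99 log units; beyond the scatter) and so weakens the compound here. The earlier step swapped a group already on the ring, whereas this one shows that replacing a hydrogen at this position can also raise the number beyond the scatter. Nothing measured here gives a reason for this step. From the compounds shown here alone, whether fluorine, a methoxy group or an amine at this position would give a similar number remains open. So does whether cyano would have the same effect with trifluoromethoxy in place of trifluoromethyl.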